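The source may report more compounds than this note shows. Statements on the series, on what has been measured and on what is new or still open speak of the compounds shown alone.

Working notes on the series. Two analogues of the shared core have been run in an assay on isolated protein (Mus musculus) for inhibition of IL15-IL15 receptor (Homo sapiens), read by resazurin assay, with stated times of 30 min and 2.5 days (on this read-out higher numbers stand for weaker inhibition and lower numbers for stronger inhibition), so far: compound 1 `CN(C(=O)CSc1nnc(Cc2nn(C)c(=O)c3ccccc23)n1C)c1ccc(Cl)cc1Cl` and compound 2 `COc1ccc(NC(=O)CSc2nnc(Cc3nn(C)c(=O)c4ccccc34)n2C)cc1`. Compound 1 returns only a limit of the assay, > 30000 nM, and no number. Compound 2 is reported as "not active" (no number reported), with no concentration given at all. For the measured compounds named here, compound 2 therefore stands without a single figure of its own, and the one further value in this assay is likewise a limit, (the limit of > 30000 nM in this assay, at which 1 of the 2 values shown sits); nothing in the measured pair places one compound above the other, and no step between measured compounds is on hand.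

The next analogue, compound 3 `Cn1c(Cc2nn(C)c(=O)c3ccccc23)nnc1SCC(=O)Nc1ccc(O)cc1`, differs from compound 2 by hydrogen in place of methyl on an oxygen on an aromatic ring, the 4-methoxyphenyl becoming 4-hydroxyphenyl. With both measured compounds showing no measurable inhibition in this assay, no step beyond the scatter is expected in either direction, and the most probable outcome is again a limit rather than a number. For compound 3 the estimate in this assay is 30000 nM, in the range 10000 nM to 100000 nM.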

Compound 3, half-maximal inhibitory concentration: "not active" (no number reported)
No number was reported for compound 3, and the estimate cannot be compared.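

In this assay compound 2 and compound 3 are both reported as "not active" with no number, and no step can be read between them. The only value in the series remains a limit: the limit of > 30000 nM in this assay, at which 1 of the 3 values shown sits.

The compounds shown leave open whether any analogue of the shared core gives a measurable inhibition, and what methoxy to hydroxy does to a numbered value.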